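From 4-methoxyphenyl to 2-hydroxy-3-methoxyphenyl in compound 3

This account rests on a few compounds, and the source may have more. Where it says the series, first, only, none or still open, it means among the compounds named here.

In a functional assay on cells (Cancer cell lines, Homo sapiens) for antiproliferative activity, read by sulforhodamine B assay, with a stated time of 48 h (a lower number here means a stronger inhibitor of growth, a higher number a weaker inhibitor of growth), compound 1 (`CN(C)c1ccc(-c2cc(-c3cccc(NS(C)(=O)=O)c3)nc(N)c2C#N)cc1`) gives 100 nM and compound 2 (`COc1ccc(-c2cc(-c3cccc(NS(C)(=O)=O)c3)nc(N)c2C#N)cc1`) gives 140 nM. Within the data shown here, the two are joined by a single measured step, a 1.4-fold higher number from compound 1 to compound 2 (0.15 log units; within the scatter), so compound 2 stands level with its only neighbour.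

Compound 3 (`COc1cccc(-c2cc(-c3cccc(NS(C)(=O)=O)c3)nc(N)c2C#N)c1O`) keeps the shared core of compound 2 and alters one group: 2-hydroxy-3-methoxyphenyl in place of 4-methoxyphenyl on an aromatic carbon. Here 2-hydroxy-3-methoxyphenyl stands in place of 4-methoxyphenyl, on an aromatic carbon ortho to a cyano group and opposite the ring nitrogen.

Among the measured compounds shown here, only one measured step bears on this change, as it also swaps a group on that same aromatic substituent. It is the step of a 1.4-fold higher number from compound 1 to compound 2 (0.15 log units; within the scatter), which gives little reason to expect a large shift in this assay. For the measured compounds named here, still, no measured compound carries a hydroxy group, so this guide is weak and the direction is only a cautious guess. The expected change is small, a 1.4-fold higher number from compound 2 to compound 3 (0.15 log units; within the scatter). Compound 3 is estimated at 200 nM, with an expected range from 50 nM to 800 nM.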

Compound 3, concentration for 50% growth inhibition: 260 nM
Beside the measured number, compound 3's estimate is 1.3-fold (0.11 log units) below it, within the range that was stated.
By their numbers in this assay, from the lowest: compounds 1, 2 and 3 (each within the scatter of the next, the first and the last beyond it).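

Placing 2-hydroxy-3-methoxyphenyl on this aromatic carbon, ortho to a cyano group and opposite the ring nitrogen, gives a 1.9-fold higher number from compound 2 to compound 3 (0.27 log units; within the scatter), so in this assay this group cannot be told apart from 4-methoxyphenyl, even though it brings a hydroxy group that neither earlier compound carries at this position. Set against 4-(dimethylamino)phenyl, the same group gives a 2.6-fold higher number from compound 1 to compound 3 (0.41 log units; beyond the scatter), the first gap at this position to lie beyond the scatter, which shows that the choice of group here can shift the number, though so far only modestly. Nothing measured here explains either step.

This change adds a hydroxy group and also replaces the 4-methoxy group with a 3-methoxy group, so the compounds shown cannot separate the two, and a plain 2-hydroxyphenyl or 3-methoxyphenyl group would be needed to tell them apart. On these data alone, it also remains open how this position would respond to something quite different from these substituted phenyl groups, such as a phenyl ring carrying a carboxylic acid or a longer chain ending in an amine.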